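The source may report more compounds than this note shows. Statements on the series, on what has been measured and on what is new or still open speak of the compounds shown alone.

The shared core of compound 1 `COc1cc(NC(C)CCCNC(=O)NNC(=O)Nc2cccc(F)c2)c2ncccc2c1` carries, on an amide-type nitrogen whose other neighbour is a carbonyl carbon, a ((3-fluorophenyl)carbamoyl)amino group. In a functional assay on HeLa cells (Homo sapiens) for inhibition, read by MTT assay, with a stated time of 72 h (on this read-out lower numbers stand for stronger inhibition and higher numbers for weaker inhibition), compound 1 gives only a limit, > 250000 nM, and no number. Compound 1 therefore stands at the weak end of the two values seen, (the limit of > 250000 nM in this assay, at which 1 of the 2 values shown sits). Compound 2 `COc1cc(NC(C)CCCNC(=O)NNC(=O)Nc2cc(C(F)(F)F)cc(C(F)(F)F)c2)c2ncccc2c1`, the other measured member of the series, gives 17000 nM in this assay. Compound 3 `COc1cc(NC(C)CCCNC(=O)Nc2ccc(F)cc2)c2ncccc2c1` has not yet been measured in this assay; it differs from compound 1 by 4-fluorophenyl in place of ((3-fluorophenyl)carbamoyl)amino on an amide-type nitrogen. Among the measured compounds shown here, no measured pair in this set shares that change, so its size is uncertain. Compound 3 is expected to move away from the limit toward a measurable value, a step of an at least 4.1-fold lower number from compound 1 to compound 3 (0.61 log units; beyond the scatter) in this assay, though the starting point being a limit leaves the true size open. Compound 3 is therefore estimated at 60000 nM, within 10000 nM and 250000 nM.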

Compound 3, half-maximal inhibitory concentration: 20000 nM
Compound 3: the middle estimate sits 3.0-fold (0.48 log units) above what was measured, and the stated range covers the measured number.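

Among the compounds shown here, putting 4-fluorophenyl in place of ((3-fluorophenyl)carbamoyl)amino on an amide-type nitrogen gives the first step that can be read, and it is large: an at least 12-fold lower number from compound 1 to compound 3 (1.09 log units; beyond the scatter) in this assay. It shows that at this position a fluorinated phenyl group set directly on that nitrogen, without the carbamoylamino stretch, is enough for compound 3 to give a measurable value. The step is only a bound and not a true size, as compound 1 gives a limit and no number: the limit of > 250000 nM in this assay, at which 1 of the 3 values shown sits.

This one change alters both the link and the place of the fluorine, and the compounds shown do not separate the two. Also open, going by these compounds, is how an amine or a carboxylic acid on that phenyl ring, or a longer chain on that nitrogen, would read in this assay.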